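The compounds below may be only part of what the source reports. "The series", "measured", "known", "first", "only" and "open" are said of these compounds alone.

Of the compounds shown here, two built on a shared core have been measured, and a third awaits its reading. Compound 1 `COc1cc(-c2cc(/C=C/C(=O)c3ccc(N)cc3)[nH]n2)cc(OC)c1OC` carries a 4-aminophenyl group on its carbonyl carbon. In a functional assay on A498 cells (Homo sapiens) for cytotoxicity, read by sulforhodamine B assay, with a stated time of 48 h, tested at 0.1 uM (a lower number here means a stronger effect, a higher number a weaker effect of the compound at the concentration tested), compound 1 gives 85%. Going by the values given here, compound 2 `COc1ccc(-c2cc(/C=C/C(=O)c3ccc(OC)c(OC)c3)[nH]n2)cc1` differs from compound 1 in more than one place, so no single step connects the two; in this assay compound 2 gives 79%. These two numbers lie within the usual scatter of each other, so neither compound can be said to act more strongly than the other: both simply show a weak effect at the concentration tested.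

Compound 3 `COc1cc(-c2cc(/C=C/C(=O)c3ccc(Cl)c(Cl)c3)[nH]n2)cc(OC)c1OC` is a single change away from compound 1: 3,4-dichlorophenyl in place of 4-aminophenyl on a carbonyl carbon. Among the compounds with values here, no measured pair shows what such a swap does in this setting, so the only guide is that both measured compounds sit at high numbers. The step is expected to be small, a number 5 percentage points lower from compound 1 to compound 3 (within the scatter), with no firm direction and not clearly beyond the scatter. Compound 3 is therefore expected to give about 80% in this assay, within a range from 60% to 100%.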

Compound 3, a percentage reported as activity, at one concentration (the size of the read-out at that concentration, not a potency): 89%
Estimate against measurement, compound 3: 9 percentage points below; low and high end bracket the measured number.
By their numbers in this assay, from the lowest: compounds 2, 1 and 3 (each within the scatter of the next).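

Going by these compounds alone, this is the first single-change comparison on the shared core: in this assay, putting 3,4-dichlorophenyl in place of 4-aminophenyl on a carbonyl carbon gives a number 4 percentage points higher from compound 1 to compound 3 (within the scatter). The group that leaves has a hydrogen-bond donor and a hydrogen-bond acceptor and the group that enters has neither, yet the two compounds cannot be told apart here, so at the concentration tested this position shows no sensitivity to this particular change. Nothing available explains why the change leaves the reading within the scatter.

The compounds shown leave open whether a different group on this carbonyl carbon, such as a carboxylic acid or a morpholine ring, would take the number clearly beyond the scatter, or whether any group there can do so while the rest of the core of compound 1 stays as it is. They also leave open whether the same swap would give a similar result on the core of compound 2, which differs from compound 1 in more than one place.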